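Naphthalen-1-yl to naphthalen-2-yl on a shared core

A few compounds are considered here, and "the series" means these few. Any claim that something is new, unique, unknown or untested is made for them only; others in the source may bear on it.

In a functional assay on C8166 cells (Homo sapiens) for cytotoxicity, read by MTT assay (on this read-out lower numbers stand for higher toxicity in this test and higher numbers for lower toxicity in this test), compound 1 `Cc1cc(S(N)(=O)=O)ccc1NC(=O)COc1ccc(Cl)cc1NC(=O)c1ccccc1` gives 207000 nM and compound 2 `Cc1cc(S(N)(=O)=O)ccc1NC(=O)COc1ccc(Cl)cc1NC(=O)/C=C/c1ccccc1` gives 163000 nM. Between these two lies a 1.3-fold lower number from compound 1 to compound 2 (0.10 log units; within the scatter).

Compound 3 `Cc1cc(S(N)(=O)=O)ccc1NC(=O)COc1ccc(Cl)cc1NC(=O)c1cccc2ccccc12` gives no number, only a limit of > 381000 nM. The steps leading to it are an at least 1.8-fold higher number from compound 1 to compound 3 (0.26 log units; that floor lies within the scatter) and an at least 2.3-fold higher number from compound 2 to compound 3 (0.36 log units; beyond the scatter), so it stands at the lower-toxicity end of the series, though only the second of these clears the scatter.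

Compound 4 `Cc1cc(S(N)(=O)=O)ccc1NC(=O)COc1ccc(Cl)cc1NC(=O)c1ccc2ccccc2c1` has the same atoms as compound 3, joined differently: naphthalen-2-yl in place of naphthalen-1-yl on a carbonyl carbon. The change is naphthalen-2-yl in place of naphthalen-1-yl on a carbonyl carbon.

The measured steps that bear on it are the same three exchanges at that carbonyl carbon, and none compares the two naphthalenyl groups directly. The largest floor among them, an at least 2.3-fold higher number from compound 2 to compound 3 (0.36 log units; beyond the scatter), is only modest, so at most a small step is expected, and any number that appears should lie lower than the limit. Compound 4 may also return only a limit.

For compound 4 the estimated value is 260000 nM, with an expected range from 130000 nM to 400000 nM. The estimate means an expected at least 1.4-fold lower number from compound 3 to compound 4 (0.16 log units; that floor lies within the scatter).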

Compound 4, half-maximal cytotoxic concentration: 37600 nM
Compound 4: middle estimate off by 6.9-fold (0.84 log units), on the high side, outside the stated range (below it).
By their numbers in this assay, from the lowest: compound 4; then compounds 2 and 1 (each within the scatter of the next). At a limit, above all of these: compound 3.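

In this assay, the exchange of naphthalen-1-yl for naphthalen-2-yl on a carbonyl carbon, which keeps the same atoms and changes only how they are joined, gives an at least 10-fold lower number from compound 3 to compound 4 (1.00 log units; beyond the scatter) and so shows that this position responds to the point of attachment alone. The phenyl and 2-phenylethenyl groups gave no step beyond the scatter between them, whereas naphthalen-2-yl gives both a 5.5-fold lower number from compound 1 to compound 4 (0.74 log units; beyond the scatter) and a 4.3-fold lower number from compound 2 to compound 4 (0.64 log units; beyond the scatter), which makes compound 4 the most toxic of the four in this assay and shows that a lower number can be reached at this position. From the compounds shown here alone, compound 3 gives only a limit, so its step to compound 4 is a floor and its true size remains unknown: the limit of > 381000 nM in this assay, at which 1 of the 4 values shown sits.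

The compounds shown leave open whether the lower number of compound 4 survives when an amine or a carboxylic acid is carried on the naphthalen-2-yl group. They also leave open what a longer chain between the carbonyl carbon and the naphthalen-2-yl group would do to the number in this assay.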